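This account rests on a few compounds, and the source may have more. Where it says the series, first, only, none or still open, it means among the compounds named here.

Of the compounds shown here, three built on one shared core have been measured in a functional assay on A2780 cells (Homo sapiens) for inhibition, read by MTT assay, with a stated time of 72 h; a lower number here means a stronger inhibitor of growth, a higher number a weaker inhibitor of growth. Compound 1 `O=S(=O)(NCCCNCc1ccc(Cl)c(C(F)(F)F)c1)c1cc(C(F)(F)F)cc(C(F)(F)F)c1` gives 5900 nM in this assay. Compound 2 `O=S(=O)(NCCCNCC1COc2ccccc2O1)c1cc(C(F)(F)F)cc(C(F)(F)F)c1` gives 1500 nM, and compound 3 `COc1cccc(CNCCCNS(=O)(=O)c2cc(C(F)(F)F)cc(C(F)(F)F)c2)c1` gives 1600 nM. Compound 3 thus stands second highest of the three numbers; its nearest neighbour is compound 2, with a 1.1-fold higher number from compound 2 to compound 3 (0.03 log units; within the scatter), and its furthest is compound 1, with a 3.7-fold lower number from compound 1 to compound 3 (0.57 log units; beyond the scatter). Compound 4 `O=S(=O)(NCCCNCc1ccc(Cl)cc1)c1cc(C(F)(F)F)cc(C(F)(F)F)c1` has not yet been measured. It differs from compound 3 in one place: 4-chlorophenyl in place of 3-methoxyphenyl on a saturated chain carbon bound to an amine nitrogen. Within the data shown here, of the measured steps, only the one ending at compound 3 from compound 1 bears on this change, and it was modest. The entering 4-chlorophenyl of compound 4 is the 4-chloro-3-(trifluoromethyl)phenyl of compound 1 without its trifluoromethyl, so compound 4 is expected to move part of the way back toward compound 1, a step of a 1.9-fold higher number from compound 3 to compound 4 (0.27 log units; within the scatter). Compound 4 is therefore estimated at 3000 nM, within a range from 1500 nM to 6500 nM.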

Compound 4, concentration for 50% growth inhibition: 1800 nM
The estimate for compound 4 lay 1.7-fold (0.22 log units) above the measured number; measured number inside the range.
By their numbers in this assay, from the lowest: compounds 2, 3 and 4 (each within the scatter of the next); then compound 1.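

In this assay, 4-chlorophenyl on a saturated chain carbon bound to an amine nitrogen stands level with 3-methoxyphenyl (a 1.1-fold higher number from compound 3 to compound 4 (0.05 log units; within the scatter)) and with 2,3-dihydro-1,4-benzodioxin-2-yl (a 1.2-fold higher number from compound 2 to compound 4 (0.08 log units; within the scatter)), so three quite different groups at this place give numbers within the scatter of one another. Hydrogen in place of trifluoromethyl on an aromatic carbon is the single change that parts compound 1 from compound 4 (a 3.3-fold lower number from compound 1 to compound 4 (0.52 log units; beyond the scatter)), which shows that among these compounds the chlorine alone does not carry compound 1 away from the others. Nothing available explains this difference.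

From the compounds shown here alone, it remains open whether a trifluoromethylphenyl without the chlorine would fall with compound 1 or with the other three. Also open, going by these compounds, is how a plain phenyl, a nitrile on that ring or a longer chain would read.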